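A few compounds are considered here, and "the series" means these few. Any claim that something is new, unique, unknown or untested is made for them only; others in the source may bear on it.

The three measured compounds share one core and differ only in the aryl group on the carbon that carries a double bond to nitrogen. Compound 1 `C(=N/N(Cc1ccccc1)Cc1ccccc1)\c1ccccc1` bears a phenyl there, and in an assay on liver (Sus scrofa) for inhibition of glucose-6-phosphatase catalytic subunit 1 (Homo sapiens), using microsomes (on this read-out higher numbers stand for weaker inhibition and lower numbers for stronger inhibition), compound 1 gives 1500 nM. Compound 2 `Clc1ccc(/C=N/N(Cc2ccccc2)Cc2ccccc2)cc1` bears a 4-chlorophenyl; in this assay compound 2 gives 240 nM, the lowest of the three numbers. Compound 3 `CCc1ccc(/C=N/N(Cc2ccccc2)Cc2ccccc2)o1` bears a 5-ethylfuran-2-yl, and in this assay compound 3 gives 330 nM, a number that sits within the scatter of compound 2, while compound 1 stands furthest away. Among the steps, a 6.3-fold lower number from compound 1 to compound 2 (0.80 log units; beyond the scatter) and a 4.5-fold lower number from compound 1 to compound 3 (0.66 log units; beyond the scatter) were both modest, whereas a 1.4-fold higher number from compound 2 to compound 3 (0.14 log units; within the scatter) stayed within the scatter.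

Compound 4 `Clc1ccc(/C=N/N(Cc2ccccc2)Cc2ccccc2)s1` is the next member: 5-chlorothiophen-2-yl in place of 4-chlorophenyl on a carbon with a double bond to nitrogen. The step that bears on it is the one in which a five-membered aromatic ring with one hetero atom likewise took the place of the 4-chlorophenyl, and that step, a 1.4-fold higher number from compound 2 to compound 3 (0.14 log units; within the scatter), did not leave the scatter. Compound 4 is therefore expected to show a 1.0-fold higher number from compound 2 to compound 4 (0.02 log units; within the scatter) in this assay, that is, no step beyond the scatter. Compound 4 is estimated at 250 nM, with a range from 100 nM to 600 nM.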

Compound 4, half-maximal inhibitory concentration: 170 nM
Compound 4: middle estimate off by 1.5-fold (0.17 log units), on the high side; measured number inside the range.
By their numbers in this assay, from the lowest: compounds 4, 2 and 3 (each within the scatter of the next); then compound 1.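

The change to 5-chlorothiophen-2-yl on a carbon with a double bond to nitrogen brings a sulfur-containing ring into this place, and the numbers stay within the scatter on both comparisons: a 1.4-fold lower number from compound 2 to compound 4 (0.15 log units; within the scatter) and a 1.9-fold lower number from compound 3 to compound 4 (0.29 log units; within the scatter). So in this assay, the place accepts a six-membered ring and five-membered rings with either hetero atom without a step beyond the scatter, and compounds 2, 3 and 4 form one group, with none of the three going against it. Compound 1, the only one with an unsubstituted ring, stands apart from this group, now also by an 8.8-fold lower number from compound 1 to compound 4 (0.95 log units; beyond the scatter), but nothing shown here explains why these numbers fall as they do.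

Compound 4 changes the ring and carries a chloro group on it, so the compounds shown do not separate the part played by the ring from that played by the chloro group, and a plain thiophen-2-yl or furan-2-yl would be needed to tell them apart. Going by these compounds, how an amine or a carboxylic acid on the ring, or a longer chain in place of the ethyl of compound 3, would read in this assay also remains open.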